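Carbonyl substituent exchange on the shared core: compound 3

The source may report more compounds than this note shows. Statements on the series, on what has been measured and on what is new or still open speak of the compounds shown alone.

Measured so far:
compound 1, `CN1[C@@H]2c3[nH]c4ccccc4c3C[C@H]1[C@H](C#N)N1[C@@H](CNC(=O)c3cccc(C(F)(F)F)c3)c3[nH]c4ccccc4c3C[C@@H]21`: 870 nM in a functional assay on BGC-823 cells (Homo sapiens) for cytotoxicity, read by MTT assay, with a stated time of 72 h; a lower number here means a stronger inhibitor, a higher number a weaker inhibitor
compound 2, `CN1[C@@H]2c3[nH]c4ccccc4c3C[C@H]1[C@H](C#N)N1[C@@H](CNC(=O)c3cc4ccccc4s3)c3[nH]c4ccccc4c3C[C@@H]21`: 240 nM in this assay

Compound 1 stands with the higher of the two numbers; its nearest neighbour is compound 2, reached by a 3.6-fold lower number from compound 1 to compound 2 (0.56 log units; beyond the scatter), a modest step that is beyond the scatter.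

Compound 3 `CN1[C@@H]2c3[nH]c4ccccc4c3C[C@H]1[C@H](C#N)N1[C@@H](CNC(=O)/C=C/c3ccccc3)c3[nH]c4ccccc4c3C[C@@H]21` is not yet measured. Its difference from compound 1 is 2-phenylethenyl in place of 3-(trifluoromethyl)phenyl on a carbonyl carbon.

Among the measured compounds shown here, only one measured step changes the group on the same carbonyl carbon, a 3.6-fold lower number from compound 1 to compound 2 (0.56 log units; beyond the scatter), and it shows that this group can be exchanged with a modest gain. For the measured compounds named here, no measured step puts 2-phenylethenyl in place of 3-(trifluoromethyl)phenyl, so the direction for compound 3 rests only on that one neighbour. A small step downward in this assay is expected for compound 3, or none beyond the scatter, and an expected 1.5-fold lower number from compound 1 to compound 3 (0.16 log units; within the scatter) is taken as the working guess. Compound 3 is therefore estimated at 600 nM in this assay, with a range from 200 nM to 1800 nM.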

Compound 3, half-maximal inhibitory concentration: 4300 nM
The estimate for compound 3 lay 7.2-fold (0.86 log units) below the measured number; the measured number lies above the stated range.
By their numbers in this assay, from the lowest: compound 2; then compound 1; then compound 3.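

In this assay, the group on the carbonyl carbon is not only open to gain: the exchange of 3-(trifluoromethyl)phenyl for 2-phenylethenyl gives a 4.9-fold higher number from compound 1 to compound 3 (0.69 log units; beyond the scatter), the first step upward at this place. Measured against 1-benzothiophen-2-yl, the same group gives an 18-fold higher number from compound 2 to compound 3 (1.25 log units; beyond the scatter), a large step, so a change confined to this one substituent moves the number in either direction from compound 1, and compound 3 is the weakest of the three. The change also shows that keeping one six-membered aromatic ring of carbon only, with no hydrogen-bond donors or acceptors counted on either group, does not keep the number in place; nothing shown here explains the loss with 2-phenylethenyl.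

Still open, from the compounds shown here alone, is whether the higher number goes with the double bond outside aromatic rings or with the departure of trifluoromethyl, a question that an unsubstituted phenyl or a saturated 2-phenylethyl group on the carbonyl carbon would separate. Also open, going by these compounds, is how this position would respond to a group of a different kind, such as a carboxylic acid or an amine carried on the aromatic ring.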